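The source may hold more compounds than are shown below. What is called first, only, known or untested is meant among the compounds shown, and "the series" means these compounds.

Measured so far in an assay on HEK293 cells for inhibition of solute carrier family 22 member 12 (Homo sapiens); a lower number here means a stronger inhibitor, a higher number a weaker inhibitor:
- compound 1 `O=S(=O)(O)CSc1nnc(Br)n1Cc1ccc(Br)c2ccccc12` gives 14400 nM
- compound 2 `O=S(=O)(CSc1nnc(Br)n1Cc1ccc(Br)c2ccccc12)Nc1cc(Cl)cnc1Cl` gives 2790 nM
- compound 3 `COc1ncccc1NS(=O)(=O)CSc1nnc(Br)n1Cc1ccc(Br)c2ccccc12` gives 4050 nM

Compound 1 stands highest of the three; its nearest neighbour is compound 3, its furthest compound 2. Compound 4 `O=S(=O)(CSc1nnc(Br)n1Cc1ccc(Br)c2ccccc12)Nc1ccc(Br)nc1` is not yet measured. It differs from compound 1 by (6-bromopyridin-3-yl)amino in place of hydroxy on a sulfonyl sulfur.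

Within the data shown here, two measured steps bear on this change, both of the same kind: a 5.2-fold lower number from compound 1 to compound 2 (0.71 log units; beyond the scatter) and a 3.6-fold lower number from compound 1 to compound 3 (0.55 log units; beyond the scatter). Between the two pyridinyl variants the gap is a 1.5-fold higher number from compound 2 to compound 3 (0.16 log units; within the scatter). A step of similar size is therefore expected for compound 4, downward, beyond the scatter: a 4.1-fold lower number from compound 1 to compound 4 (0.61 log units; beyond the scatter). Compound 4 is estimated at 3500 nM, with a range from 1500 nM to 8000 nM.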

Compound 4, half-maximal inhibitory concentration: 2200 nM
Compound 4: middle estimate off by 1.6-fold (0.20 log units), on the high side, within the range that was stated.
By their numbers in this assay, from the lowest: compounds 4, 2 and 3 (each within the scatter of the next); then compound 1.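

In this assay the (6-bromopyridin-3-yl)amino group on the sulfonyl sulfur also gives a step beyond the scatter when it replaces hydroxy (a 6.5-fold lower number from compound 1 to compound 4 (0.82 log units; beyond the scatter)), so the downward step now holds for all three pyridinyl sulfonamides shown. Among the pyridinyl groups the gaps stay within the scatter (a 1.8-fold lower number from compound 3 to compound 4 (0.27 log units; within the scatter); a 1.3-fold lower number from compound 2 to compound 4 (0.10 log units; within the scatter)), so these numbers do not separate them. No measurement at hand explains these numbers.

From the compounds shown here alone, whether a phenylamino or a plain methylamino group on the sulfonyl sulfur gives a step of similar size stays open, so the share of the pyridine ring in the step cannot yet be read.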